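The source may hold more compounds than are shown below. What is called first, only, known or untested is meant among the compounds shown, and "the series" means these compounds.

Measured so far:
compound 1, `c1ccc(Nc2nc(N3CCNCC3)c3cc[nH]c3n2)cc1` — 89.6%
compound 2, `N[C@H]1CCCN(c2nc(Nc3cccc(Cl)c3)nc3[nH]ccc23)C1` — 38.3%
compound 3, `N[C@@H]1CCCN(c2nc(Nc3cccc(Cl)c3)nc3[nH]ccc23)C1` — 72.5%

In an assay on isolated protein for inhibition of serine/threonine-protein kinase PAK 4 (Homo sapiens), read by filter binding, with a stated time of 20 min, tested at 2 uM (on this read-out higher numbers stand for more inhibition at the one concentration tested (going by the name of the read-out) and lower numbers for less inhibition), compound 3 stands second of the three, below compound 1 and above compound 2, both gaps beyond the scatter. Among the measured compounds shown here, the one measured step that touches it is a number 34.2 percentage points higher from compound 2 to compound 3 (beyond the scatter), a large change that rests on (the fact that compounds 2 and 3 differ only in the configuration as drawn), so how the amine is arranged on the saturated ring matters. Compound 4, `CC1(N)CCN(c2nc(Nc3cccc(Cl)c3)nc3[nH]ccc23)CC1`, carries 4-amino-4-methylpiperidin-1-yl in place of 3-aminopiperidin-1-yl on an aromatic carbon, which removes the stereocentre and moves the amine. For the measured compounds named here, no measured step covers this change, so the expectation is uncertain; a modest drop is estimated, a number 17.5 percentage points lower from compound 3 to compound 4 (beyond the scatter). Compound 4 is expected to give about 55%, in the range 25% to 85%.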

Compound 4, a percentage reported as inhibition, at one concentration (the size of the read-out at that concentration, not a potency): 35.5%
For compound 4 the middle estimate is 19.5 percentage points above the measured one; measured number inside the range.
By their numbers in this assay, from the lowest: compounds 4 and 2 (each within the scatter of the next); then compound 3; then compound 1.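

Replacing 3-aminopiperidin-1-yl with 4-amino-4-methylpiperidin-1-yl at this position gives a number 37 percentage points lower from compound 3 to compound 4 (beyond the scatter), but also a number 2.8 percentage points lower from compound 2 to compound 4 (within the scatter). The size of this change therefore depends on which drawn form of the 3-aminopiperidin-1-yl group serves as the starting point. That contrast rests on one difference between the two starting compounds: the fact that compounds 2 and 3 differ only in the configuration as drawn

The new group adds a methyl and moves the amine in one step, so the compounds shown do not separate these two changes. A 4-aminopiperidin-1-yl group, with the amine moved and no methyl, would address that question.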